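Replacing the aryl selenide of compound 1 with a hydroxybutynyl chain

The source may hold more compounds than are shown below. What is called first, only, known or untested is meant among the compounds shown, and "the series" means these compounds.

Measured compounds:
compound 1 `CCOC(=O)c1cc([Se]c2ccccc2C)c2cc(OC)ccc2n1`: 38900 nM
compound 2 `CCOC(=O)c1cc([Se]c2ccccc2)c2cc(C)ccc2n1`: 12000 nM
compound 3 `COc1ccc([Se]c2cc(-c3ccc(O)cc3)nc3ccc(OC)cc23)cc1`: 59200 nM

In a functional assay on SK-MEL-147 cells (Homo sapiens) for cytotoxicity, read by MTT assay, with a stated time of 24 h (on this read-out lower numbers stand for an effect already at smaller amounts and higher numbers for an effect only at larger amounts of compound), compound 1 stands second highest of the three numbers. Compound 3 lies within the scatter of it, while compound 2 gives a number beyond the scatter below it. No pair of these compounds differs in a single place, so none of them isolates a single change.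

Compound 4 `CCOC(=O)c1cc(C#CCCO)c2cc(OC)ccc2n1` is not yet measured. It differs from compound 1 in one place: a group of 5 heavy atoms (4 carbon, 1 oxygen; no ring) in place of a group of 8 heavy atoms (7 carbon, 1 selenium; one six-membered aromatic ring of carbon only), on an aromatic carbon. The change sits on the core, on the aromatic carbon opposite the ring nitrogen and meta to the ethoxycarbonyl group. Nothing measured here separates this change. The step of a 2.1-fold higher number from compound 1 to compound 4 (0.31 log units; beyond the scatter) is the author's estimate, towards a higher number, of a size beyond the scatter. Compound 4 is therefore expected to give about 80000 nM in this assay, within 25000 nM to 250000 nM.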

Compound 4, half-maximal effective concentration: > 150000 nM
Compound 4: no number, only a limit (the forecaster's own chance of this, stated with the estimate: 30%); middle value at least 1.8-fold (0.27 log units) away from the limit.
By their numbers in this assay, from the lowest: compound 2; then compounds 1 and 3 (each within the scatter of the next). At a limit, above all of these: compound 4.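

In this assay compound 4 gives > 150000 nM, which is a limit of the assay and not a number. Putting 4-hydroxybut-1-yn-1-yl in place of the aryl selenide on the aromatic carbon opposite the ring nitrogen gives an at least 3.8-fold higher number from compound 1 to compound 4 (0.58 log units; beyond the scatter). This is the only single-place change shown, and it shows that the group on this carbon matters in this assay. The compounds shown do not separate the part played by the selenium from that of the aromatic ring. Going by these compounds, how an amine, a carboxylic acid or a saturated butyl chain on this carbon would read remains open.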